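Swapping the chain hydroxyl for an alkene

A few compounds are considered here, and "the series" means these few. Any claim that something is new, unique, unknown or untested is made for them only; others in the source may bear on it.

Compound 1, `CC(C)n1cnc2ncnc(N)c21`, gives 20000 nM in an assay on CHO cells for displacement of a labelled ligand from adenosine receptor A1 (Homo sapiens); a higher number here means a weaker inhibitor, a lower number a stronger inhibitor.
Compound 2, `Nc1ncnc2ncn(CCCO)c12`, reaches only a limit of this assay, > 100000 nM.
Compound 3, `Nc1ncnc2c1nc(Br)n2CCCO`, gives 1000 nM.

Among these, compound 3 holds the lowest of the two numbers; its nearest neighbour is compound 1, which sits well above it. Compound 4, `C=CCCn1c(Br)nc2c(N)ncnc21`, differs from compound 3 by vinyl in place of hydroxymethyl on a saturated chain carbon, two bonds along the chain from an aromatic nitrogen. Going by the values given here, the one measured step that bears on this is an at least 5.0-fold higher number from compound 1 to compound 2 (0.69 log units; beyond the scatter), where a chain carrying a hydroxyl replaced a plain alkyl group and binding weakened. Removing the hydroxyl from the chain of compound 3 is therefore expected to move the number downward, by about a 2.5-fold lower number from compound 3 to compound 4 (0.40 log units; beyond the scatter). Compound 4 is estimated at 400 nM, with a likely range from 100 nM to 2000 nM.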

Compound 4, inhibition constant: 4900 nM
Estimate against measurement, compound 4: 12-fold (1.09 log units) below; the measured number lies above the stated range.
By their numbers in this assay, from the lowest: compound 3; then compound 4; then compound 1. At a limit, above all of these: compound 2.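

In this assay, the change away from the 3-hydroxypropyl chain costs binding: a 4.9-fold higher number from compound 3 to compound 4 (0.69 log units; beyond the scatter). A chain hydroxyl can therefore go with stronger binding, the opposite direction to the earlier step, in which 3-hydroxypropyl replacing isopropyl came with weaker binding. Across these two pairs, the effect of the hydroxyl-bearing chain is not the same, though the groups it was compared with also differ.

Going by these compounds, compound 2 stands at a limit, leaving the size of that earlier step open: the limit of > 100000 nM in this assay, at which 1 of the 4 values shown sits. Where a plain butyl or a 3-aminopropyl chain would fall relative to compound 3 and compound 4 also remains open.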